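Swapping an Ester for a Diethylamide on a Dienoate Chain

The source may report more compounds than this note shows. Statements on the series, on what has been measured and on what is new or still open speak of the compounds shown alone.

Three related compounds have been measured in a physicochemical assay for lipophilicity; on this read-out lower numbers stand for lower lipophilicity and higher numbers for higher lipophilicity. Compound 1 `CC(/C=C/CC(C)CCCC(C)C)=C\C(=O)OCC(C)C` gives 7.69. Compound 2 `C/C=C/COC(=O)/C=C(C)/C=C/CC(C)CCCC(C)(C)OC` gives 6.07, the lowest of the three numbers, and compound 3 `CCOC(=O)/C=C(C)/C=C/CC(C)CCCC(C)(C)OCC` gives 6.08, a value within the scatter of compound 2. Compound 1 lies well beyond the scatter above compound 2.

Compound 4 `CCN(CC)C(=O)/C=C(C)/C=C/CC(C)CCCC(C)(C)OC` is not yet measured. It differs from compound 2 in one place: diethylamino in place of (but-2-en-1-yl)oxy on a carbonyl carbon. The ester oxygen with its four-carbon chain leaves, and a diethylamino group enters on the same carbonyl carbon.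

Among the measured compounds shown here, no step between measured compounds covers this kind of change, so the expectation rests on the structures alone. The step of a number 1.07 log units lower from compound 2 to compound 4 (beyond the scatter) is expected to be downward and beyond the scatter. Compound 4 is therefore estimated at 5 in this assay, with a range from 4.4 to 5.6.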

Compound 4, partition coefficient: 4.82
Beside the measured number, compound 4's estimate is 0.18 log units above it; the range from low to high includes it.
By their numbers in this assay, from the lowest: compound 4; then compounds 2 and 3 (each within the scatter of the next); then compound 1.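

In this assay, the first change made at this carbonyl carbon gives a large step, a number 1.25 log units lower from compound 2 to compound 4 (beyond the scatter), so the read-out responds strongly to what sits on this carbonyl carbon. The step appears even though (but-2-en-1-yl)oxy and diethylamino each carry 5 heavy atoms and no ring, so heavy-atom count alone does not set the value here. Nothing measured alongside these compounds accounts for the size of the step.

Open, on these data alone, is how a smaller dimethylamino group or a free carboxylic acid would read on the same carbonyl carbon. Also open, as far as these compounds go, is whether diethylamino would give a similar step on the core of compound 3.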